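The source may hold more compounds than are shown below. What is called first, only, known or untested is meant among the compounds shown, and "the series" means these compounds.

Compound 1 (`O=C(c1ccc(Cl)nc1)N1CCC(NS(=O)(=O)c2cc(S(=O)(=O)c3ccccc3)ccc2C(F)(F)F)CC1`), compound 2 (`CN(C)c1ccc(C(=O)N2CCC(NS(=O)(=O)c3cc(S(=O)(=O)c4ccccc4)ccc3C(F)(F)F)CC2)cn1`) and compound 3 (`CC(C)(O)CCN1CCC(NS(=O)(=O)c2cc(S(=O)(=O)c3ccccc3)ccc2C(F)(F)F)CC1`) share a core and differ in the group on an amine nitrogen in a ring. In a physicochemical assay for solubility, at pH 7.4 (on this read-out higher numbers stand for higher solubility and lower numbers for lower solubility), compound 1 gives a reading (1700 nM), and compound 2 gives another (6700 nM).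

Compound 3 reads > 100000 nM as a limit of the assay and not a number. It stands highest of the three, as the large steps show (an at least 58-fold higher number from compound 1 to compound 3 (1.76 log units; beyond the scatter); an at least 14-fold higher number from compound 2 to compound 3 (1.17 log units; beyond the scatter)).

Compound 4 (`O=C(CC1CCNCC1)N1CCC(NS(=O)(=O)c2cc(S(=O)(=O)c3ccccc3)ccc2C(F)(F)F)CC1`) has ((piperidin-4-yl)methyl)carbonyl in place of 3-hydroxy-3-methylbutyl (((piperidin-4-yl)methyl)carbonyl in place of 3-hydroxy-3-methylbutyl on an amine nitrogen in a ring). This restores a carbonyl on that nitrogen, as in compound 1 and compound 2, but the group now carries a six-membered non-aromatic ring with 1 hetero atom. The two large steps therefore suggest some fall, though probably only part of their size. The modest step (a 3.9-fold higher number from compound 1 to compound 2 (0.60 log units; beyond the scatter)) shows that a change within such a carbonyl group can move the number upward.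

The expected change is moderate and downward (an at least 2.5-fold lower number from compound 3 to compound 4 (0.39 log units; beyond the scatter)). For compound 4 the estimated value is 40000 nM, with an expected range from 10000 nM to 100000 nM.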

Compound 4, solubility: > 100000 nM
Compound 4: no number, only a limit; the forecaster's own chance of this, stated with the estimate: 30%; at least 2.5-fold (0.39 log units) between middle value and limit.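

Among these compounds, compound 4 shows that a carbonyl on the amine nitrogen in a ring can go with a reading at the limit of this assay, whereas the earlier compounds paired that carbonyl only with measured numbers. Putting (piperidin-4-yl)methyl on the carbonyl carbon in place of the aromatic group gives an at least 14-fold higher number from compound 2 to compound 4 (1.17 log units; beyond the scatter) and an at least 58-fold higher number from compound 1 to compound 4 (1.76 log units; beyond the scatter) with the carbonyl itself kept. The step between compound 3 and compound 4 cannot be read because both readings are limits and not numbers: the limit of > 100000 nM in this assay, at which 2 of the 4 values shown sit.

The compounds shown leave open how far past that limit either compound lies. They also leave open whether the hetero atom of the ring goes with the high reading, a question that a cyclohexylmethyl group on the same carbonyl carbon would address.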